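The source may hold more compounds than are shown below. What is called first, only, known or untested is meant among the compounds shown, and "the series" means these compounds.

Within the data shown here, compound 1 `COc1ccc(CN(C(=O)CSc2nc3ccccc3s2)c2cc(OC)c(OC)c(OC)c2)cc1O` holds the lower of the two numbers so far in a functional assay on MGC-803 cells (Homo sapiens) for antiproliferative activity, read by MTT assay, with a stated time of 48 h; on this read-out higher numbers stand for weaker inhibition and lower numbers for stronger inhibition: compound 1 gives 35 nM. Compound 2 `COc1ccc(CN(C(=O)CSc2nc3ccccc3s2)c2cc(OC)c(OC)c(OC)c2)cc1C(F)(F)F`, which differs only by trifluoromethyl in place of hydroxy on an aromatic carbon, gives 25200 nM in this assay, a step of a 720-fold higher number from compound 1 to compound 2 (2.86 log units; beyond the scatter). Compound 3 `COc1ccc(CN(C(=O)CSc2nc3ccccc3s2)c2cc(OC)c(OC)c(OC)c2)cc1Br` is the next single change from compound 1: bromo in place of hydroxy on an aromatic carbon. Among the measured compounds shown here, only the step to compound 2 speaks to this change; it also removed the hydroxy, and it was large. Bromo is not trifluoromethyl, so the loss need not match, but a step in the same direction and of substantial size, well beyond the scatter, is expected in this assay. The expected shift is a 57-fold higher number from compound 1 to compound 3 (1.76 log units; beyond the scatter). Compound 3 is estimated at 2000 nM, with a range from 200 nM to 20000 nM.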

Compound 3, half-maximal inhibitory concentration: 852 nM
Compound 3: middle estimate off by 2.3-fold (0.37 log units), on the high side; the range from low to high includes it.
By their numbers in this assay, from the lowest: compound 1; then compound 3; then compound 2.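

In this assay, a second replacement of the hydroxy also raises the number, with a 24-fold higher number from compound 1 to compound 3 (1.39 log units; beyond the scatter) for bromo, so the loss at this position is not peculiar to trifluoromethyl. The two replacements are also far apart from each other, with a 30-fold lower number from compound 2 to compound 3 (1.47 log units; beyond the scatter) on going to bromo, so the outcome here depends on which group enters and not only on the hydroxy leaving. Nothing available explains either step.

From the compounds shown here alone, whether any other group can match compound 1 at this position stays open; an amine or a hydroxymethyl group in the same place, ortho to a methoxy group, would test that. Also open, going by these compounds, is whether chloro or fluoro continues the difference between bromo and trifluoromethyl.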